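Solubility notes on the ring exchange at compound 1

The compounds below may be only part of what the source reports. "The series", "measured", "known", "first", "only" and "open" are said of these compounds alone.

Of the compounds shown here, two have been measured in a physicochemical assay for solubility, in phosphate buffer, measured as kinetic solubility, with a stated time of 24 h, at pH 6.5; on this read-out lower numbers stand for lower solubility and higher numbers for higher solubility. Compound 1 `CC(C)Oc1cc(Oc2ccc(S(C)(=O)=O)cc2)cc(-c2cncc(=O)[nH]2)c1` gives 118000 nM in this assay, the lower of the two numbers. Compound 2 `CC(C)Oc1cc(Oc2cnc(C(=O)N(C)C)nc2)cc(-c2nccc(=O)[nH]2)c1` gives 332000 nM in this assay, a higher number than compound 1, and the gap between them lies beyond the usual scatter. Among the compounds with values here, compound 2 differs from compound 1 in several places at once, so no single step between measured compounds can be read from this pair, and no step of any kind between measured compounds is available.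

Compound 3 `COc1cnc(-c2cc(Oc3ccc(S(C)(=O)=O)cc3)cc(OC(C)C)c2)[nH]c1=O` has not yet been measured. It differs from compound 1 in one place: a group of 9 heavy atoms (5 carbon, 2 nitrogen, 2 oxygen; one six-membered aromatic ring with 2 hetero atoms) in place of a group of 7 heavy atoms (4 carbon, 2 nitrogen, 1 oxygen; one six-membered aromatic ring with 2 hetero atoms), on an aromatic carbon. Both groups hold one six-membered aromatic ring with 2 hetero atoms and 1 hydrogen-bond donor; the entering group holds 3 hydrogen-bond acceptors against 2 in the group that leaves.

Within the data shown here, with no comparable step on hand, the step from compound 1 to compound 3 is expected to stay within the scatter, in no clear direction, and is estimated as a 1.1-fold lower number from compound 1 to compound 3 (0.03 log units; within the scatter). Compound 3 is therefore expected to give about 110000 nM in this assay, with an estimated range from 40000 nM to 300000 nM.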

Compound 3, solubility: 7100 nM
The estimate for compound 3 lay 15-fold (1.19 log units) above the measured number, and the stated range ends above it.
By their numbers in this assay, from the lowest: compound 3; then compound 1; then compound 2.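

The step of a 17-fold lower number from compound 1 to compound 3 (1.22 log units; beyond the scatter) shows that in this assay the group on this aromatic carbon, meta to a large group and meta to an isopropoxy group, cannot be exchanged freely, even between two groups that each hold one six-membered aromatic ring with 2 hetero atoms and 1 hydrogen-bond donor. The counts under comparison differ only modestly, with 9 heavy atoms and 3 hydrogen-bond acceptors in the entering group against 7 and 2 in the group that leaves, yet the step is large and lies beyond the scatter, which the earlier pair, differing in several places at once, could not show. No measurement at hand bears on the origin of this step.

The compounds shown do not separate the contribution of the added heavy atoms from that of the different arrangement of atoms within the ring, and one step cannot show whether the same size of change would hold on another part of the series. As far as these compounds go, how a ring carrying an amine or a carboxylic acid at this position would read in this assay remains open.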